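Methylpiperazine Amide Predicted from the Piperidine Analogue

The compounds below may be only part of what the source reports. "The series", "measured", "known", "first", "only" and "open" are said of these compounds alone.

The series shares a core carrying a chloro-substituted bicyclic heteroaromatic ring linked through sulfur to a three-carbon chain ending in an amide or amine. Compound 1 `CS(=O)(=O)C1CCN(C(=O)CCSc2nc3cc(Cl)ccc3o2)CC1` gives 2.6 mL/min/g in an ADME assay on microsomes from liver (Mus musculus) for metabolic stability, read by LC-MS, using NADPH, with a stated time of 45 min, tested at 0.5 uM; on this read-out lower numbers stand for slow clearance and higher numbers for fast clearance. Compound 2 `O=C(CCSc1nc2cc(Cl)ccc2o1)N1CCCCC1` gives 128 mL/min/g in this assay, and compound 3 `Clc1ccc2oc(SCCCN3CCCC3)nc2c1` gives 10.4 mL/min/g. Compound 2 thus stands highest of the three numbers, with compound 3 its nearest neighbour and compound 1 the furthest.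

Compound 4 `CN1CCN(C(=O)CCSc2nc3cc(Cl)ccc3o2)CC1` is the unmeasured member. It differs from compound 2 by 4-methylpiperazin-1-yl in place of piperidin-1-yl on a carbonyl carbon. Among the compounds with values here, the only measured step that touches the amide end of the molecule is a 49-fold higher number from compound 1 to compound 2 (1.69 log units; beyond the scatter), where the methylsulfonyl group was removed from the saturated ring. That step shows how strongly a single change on the ring attached to the carbonyl can move this assay. The move from compound 2 to compound 4 is different in kind, so its size is uncertain, but the two other measured compounds both sit well below compound 2, which suggests a downward step beyond the scatter. Compound 4 is therefore expected to give 25 mL/min/g in this assay, within a range of 8 mL/min/g to 70 mL/min/g, a step of a 5.1-fold lower number from compound 2 to compound 4 (0.71 log units; beyond the scatter) that is estimated, not measured.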

Compound 4, intrinsic clearance in a liver preparation (reported as CLH), per the amount of preparation that the assay uses: 41.5 mL/min/g
The estimate for compound 4 lay 1.7-fold (0.22 log units) below the measured number, and the stated range covers the measured number.
By their numbers in this assay, from the lowest: compound 1; then compound 3; then compound 4; then compound 2.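

In this assay, putting 4-methylpiperazin-1-yl in place of piperidin-1-yl on a carbonyl carbon gives a 3.1-fold lower number from compound 2 to compound 4 (0.49 log units; beyond the scatter), so exchanging the whole ring at this position moves the number beyond the scatter. Read beside a 49-fold higher number from compound 1 to compound 2 (1.69 log units; beyond the scatter), this shows that the ring on the carbonyl carbon need not carry methylsulfonyl for the number to fall below that of compound 2, although the fall here is the smaller of the two steps. Nothing measured here bears on what lies behind this step.

The compounds shown leave open whether the fall belongs to the second ring nitrogen or to its methyl group, a question that the unsubstituted piperazin-1-yl or the morpholin-4-yl amide would address. They also leave open whether the same exchange would move the number by a similar amount on a chain without the carbonyl, as in compound 3, whose end differs from compound 2 in more than one place.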